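Three hydroxyphenyl pyridines against human topoisomerase 1

A few compounds are considered here, and "the series" means these few. Any claim that something is new, unique, unknown or untested is made for them only; others in the source may bear on it.

Compound 1 `Oc1ccc(-c2cc(-c3cccc(O)c3)nc(-c3cccc(O)c3)c2)cc1`: 0%
Compound 2 `Oc1ccccc1-c1cc(-c2ccccc2O)nc(-c2ccccc2O)c1`: 0%

In an assay on isolated protein for inhibition of DNA topoisomerase 1 (Homo sapiens), with a stated time of 30 min, tested at 100 uM (on this read-out higher numbers stand for more inhibition at the one concentration tested (going by the name of the read-out) and lower numbers for less inhibition), compound 1 gives 0%, and compound 2 gives 0%, so the two stand level within the scatter. Compound 3 `Oc1cccc(-c2cc(-c3cccc(O)c3)nc(-c3cccc(O)c3)c2)c1` has not been measured. It differs from compound 1 by 3-hydroxyphenyl in place of 4-hydroxyphenyl on an aromatic carbon. Going by the values given here, no step between measured compounds is known, so nothing sets a size to compare; with both measured values at the floor of this assay, the step is expected to stay within the scatter, in no particular direction. Compound 3 is therefore estimated to give 3%, with a range from 0% to 15%. This estimate means an expected step of a number 3 percentage points higher from compound 1 to compound 3 (within the scatter).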

Compound 3, a percentage reported as inhibition, at one concentration (the size of the read-out at that concentration, not a potency): 0%
Compound 3: middle estimate off by 3 percentage points, on the high side; low and high end bracket the measured number.
By their numbers in this assay, from the lowest: compounds 1, 2 and 3 (each within the scatter of the next).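

In this assay, 3-hydroxyphenyl in place of 4-hydroxyphenyl, on the aromatic carbon opposite the ring nitrogen, gives no change at the digits printed from compound 1 to compound 3 (within the scatter). Going by these compounds alone, this is the first step read at this position, and it shows that this swap alone does not lift the read-out off its floor, though a step between values at the floor sets no size for the change. Nothing on hand offers an explanation for this flat result. Still open, going by these compounds, is whether an aminophenyl or carboxyphenyl group at this position would give any inhibition.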